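The source may report more compounds than this note shows. Statements on the series, on what has been measured and on what is new or still open speak of the compounds shown alone.

Measured compounds:
compound 1 `CCc1ccc(N(CC(C)C)S(=O)(=O)c2ccc3c(c2)C(=O)CC(C(C)C2CCOCC2)O3)cc1` gives 4.93
compound 2 `CCc1ccc(N(CC(C)C)S(=O)(=O)c2ccc3oc(C4CCOCC4)cc(=O)c3c2)cc1` gives 4.5

Both numbers come from a physicochemical assay for lipophilicity, at pH 7.4; a higher number here means a more lipophilic compound, a lower number a more polar compound. Compound 1 stands highest of the two, and the nearest, compound 2, lies lower by more than the usual scatter. Compound 3 `CCc1ccc(N(CC(C)C)S(=O)(=O)c2ccc3c(c2)C(=O)CC(C2CCN(S(C)(=O)=O)CC2)O3)cc1` is not yet measured. It differs from compound 1 in one place: 1-(methylsulfonyl)piperidin-4-yl in place of 1-(oxan-4-yl)ethyl on a saturated ring carbon. Among the measured compounds shown here, no measured pair shows this change, so its size must be estimated. A downward step beyond the scatter is expected for compound 3, a number 1.33 log units lower from compound 1 to compound 3 (beyond the scatter). Compound 3 is therefore estimated at 3.6 in this assay, between 3 and 4.3.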

Compound 3, distribution coefficient: 3.31
Compound 3: middle estimate off by 0.29 log units, on the high side, within the range that was stated.
By their numbers in this assay, from the lowest: compound 3; then compound 2; then compound 1.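

In this assay, putting 1-(methylsulfonyl)piperidin-4-yl in place of 1-(oxan-4-yl)ethyl on this saturated ring carbon, next to the ring oxygen, is a large change: a number 1.62 log units lower from compound 1 to compound 3 (beyond the scatter). Among the compounds shown here, it is the first step measured at this position, and it shows that the number here depends strongly on the group carried. No measurement available bears on the cause of this step.

Going by these compounds, the two groups differ in several features at once, so the share of the methylsulfonyl group stays open. An unsubstituted piperidine amine or an N-acetyl piperidine at this carbon could begin to separate those features.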